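The source may hold more compounds than are shown below. What is called first, only, known or untested is meant among the compounds shown, and "the series" means these compounds.

In a functional assay on Jurkat cells (Homo sapiens) for antiproliferative activity, read by MTT assay, with a stated time of 72 h (on this read-out higher numbers stand for weaker inhibition and lower numbers for stronger inhibition), compound 1 (`COc1ccccc1-c1c(C(=O)c2cc(OC)c(OC)c(OC)c2)sc2ccccc12`) gives 2900 nM and compound 2 (`COc1cc(C(=O)c2sc3ccccc3c2Nc2ccc(C)cc2)cc(OC)c1OC`) gives 1700 nM, so the two numbers lie within the scatter of each other. Compound 3 (`CCOc1ccc(Nc2c(C(=O)c3cc(OC)c(OC)c(OC)c3)sc3ccccc23)cc1`) differs from compound 2 in one place: ethoxy in place of methyl on an aromatic carbon. Within the data shown here, the only measured step, a 1.7-fold lower number from compound 1 to compound 2 (0.23 log units; within the scatter), exchanged a whole group on the shared core and did not test this methyl, so it is a weak guide. No step beyond the scatter is expected in this assay. The expected step is a 1.2-fold lower number from compound 2 to compound 3 (0.08 log units; within the scatter). The estimated value for compound 3 is 1400 nM, within a range from 350 nM to 5000 nM.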

Compound 3, half-maximal inhibitory concentration: 300 nM
Compound 3: middle estimate off by 4.7-fold (0.67 log units), on the high side; measured number below the stated range.
By their numbers in this assay, from the lowest: compound 3; then compounds 2 and 1 (each within the scatter of the next).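

In this assay the para substituent on this ring matters: exchanging only methyl for ethoxy gives a 5.7-fold lower number from compound 2 to compound 3 (0.75 log units; beyond the scatter) and so moves the number beyond the scatter, which the earlier exchange of a whole group did not do. Replacing 2-methoxyphenyl with (4-ethoxyphenyl)amino gives a 9.7-fold lower number from compound 1 to compound 3 (0.99 log units; beyond the scatter) in the same assay. No measurement here explains this drop. Whether the oxygen or the extra length of the ethoxy group accounts for the step remains open, as does the effect of a propoxy or dimethylamino group at this place.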